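Removing a methyl from the aryl ether oxygen of compound 1

This account rests on a few compounds, and the source may have more. Where it says the series, first, only, none or still open, it means among the compounds named here.

Compound 1 `COc1ccc(-c2cc3c(OC)cc(OC)cc3n(C)c2=O)cc1` is a weak inhibitor in a functional assay on MCF7 cells (Homo sapiens) for cytotoxicity, read by colorimetric assay and MTT assay (a lower number here means a stronger inhibitor, a higher number a weaker inhibitor), giving 10000 nM. Its two measured relatives carry a longer chain on the aromatic nitrogen: compound 2 `COC(=O)CCn1c(=O)c(-c2ccc(OC)cc2)cc2c(OC)cc(OC)cc21` gives 10000 nM, and compound 3 `COc1ccc(-c2cc3c(OC)cc(OC)cc3n(CCC#N)c2=O)cc1` gives 10000 nM. Compound 1 is level with both at the digits shown; the steps are no change at the digits printed from compound 1 to compound 2 (within the scatter), no change at the digits printed from compound 1 to compound 3 (within the scatter) and no change at the digits printed from compound 2 to compound 3 (within the scatter).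

Compound 4 `COc1cc(OC)c2cc(-c3ccc(O)cc3)c(=O)n(C)c2c1` has not yet been measured in this assay. It differs from compound 1 in one place: hydrogen in place of methyl on an oxygen on an aromatic ring. Within the data shown here, none of the measured steps touches this oxygen; all three concern the chain on the aromatic nitrogen, and each was flat within the scatter. So there is no direct guide for the change to compound 4, only the observation that the shared core has stayed at the same weak level through every change tried so far. On that basis the step of no change at the digits printed from compound 1 to compound 4 (within the scatter) is expected to lie within the scatter, with compound 4 estimated at 10000 nM, in the range 4000 nM to 25000 nM.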

Compound 4, half-maximal inhibitory concentration: 10000 nM
Compound 4: the middle estimate sits on the measured number at the digits printed, and the stated range covers the measured number.
By their numbers in this assay, from the lowest: compounds 1, 2, 3 and 4 (each within the scatter of the next).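

Among these compounds, the earlier compounds differ only in the chain on the aromatic nitrogen, so compound 4 is the first here to alter a different place: an oxygen on an aromatic ring, where methoxy becomes hydroxy. In this assay the step reads no change at the digits printed from compound 1 to compound 4 (within the scatter), so replacing the methyl on this oxygen with hydrogen does not separate the two compounds, and the flat picture from the chain changes extends to this second place. No evidence is available on why the two compounds read alike.

The compounds shown leave open whether an ethyl group or a longer chain on this oxygen, or an amine or a carboxylic acid in place of the hydroxy, would shift the value. Also open, as far as these compounds go, is whether the same swap at the other methoxy groups of the shared core would read the same.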